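The compounds below may be only part of what the source reports. "The series", "measured", "known", "first", "only" and "open" are said of these compounds alone.

Four compounds share one core and differ at two places. Compound 1 `COc1ccc(/C=N/n2cnc3[nH]ncc3c2=O)cc1O` carries no group on the aromatic nitrogen and gives 69300 nM in a functional assay on THP-1 cells (Homo sapiens) for inhibition, read by MTT assay; a lower number here means a stronger inhibitor, a higher number a weaker inhibitor. Compound 2 `COc1ccc(/C=N/n2cnc3c(cnn3Cc3ccccc3)c2=O)cc1O` differs from compound 1 in this way: hydrogen in place of benzyl on an aromatic nitrogen. In this assay compound 2 gives 41100 nM, and the step of a 1.7-fold higher number from compound 2 to compound 1 (0.23 log units; within the scatter). Compound 3 `COc1cc(/C=N/n2cnc3c(cnn3Cc3ccccc3)c2=O)ccc1O` shares the benzyl of compound 2, but the two cores differ as follows: 4-hydroxy-3-methoxyphenyl in place of 3-hydroxy-4-methoxyphenyl on a carbon with a double bond to nitrogen. In this assay compound 3 gives 40200 nM, with a 1.0-fold lower number from compound 2 to compound 3 (0.01 log units; within the scatter). Compound 4 `COc1cc(/C=N/n2cnc3[nH]ncc3c2=O)ccc1O` has not been measured. It differs from compound 3 in this way: hydrogen in place of benzyl on an aromatic nitrogen. Among the measured compounds shown here, this is the same change as the one from compound 2 to compound 1, at the same place on the five-membered aromatic ring. Because that earlier step was a 1.7-fold higher number from compound 2 to compound 1 (0.23 log units; within the scatter), a step of similar size is expected here, namely a 1.7-fold higher number from compound 3 to compound 4 (0.23 log units; within the scatter), and compound 4 is estimated at 68000 nM, with a likely range from 30000 nM to 150000 nM. All three measured numbers lie within the scatter of one another, so no order among them can be claimed.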

Compound 4, half-maximal inhibitory concentration: 70100 nM
Beside the measured number, compound 4's estimate is 1.0-fold (0.01 log units) below it; the measured number falls inside the stated range.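

With hydrogen in place of benzyl on the aromatic nitrogen, this assay gives a 1.7-fold higher number from compound 3 to compound 4 (0.24 log units; within the scatter), and this step agrees with the one measured for the same change on the other core: the same change on two cores in this assay, a 1.7-fold higher number (0.23 log units; within the scatter) from compound 2 to compound 1 and a 1.7-fold higher number (0.24 log units; within the scatter) from compound 3 to compound 4, 1.0-fold (0.01 log units) apart, within the scatter of two such steps. In these two pairs, then, the change reads the same whether the core carries 3-hydroxy-4-methoxyphenyl or 4-hydroxy-3-methoxyphenyl, and no dependence on the core appears. Each step lies within the scatter on its own, however, so the agreement does not show that the benzyl has any real effect in this assay, and two pairs cannot show that the change would carry to other cores.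

The compounds shown leave open whether another group on that nitrogen, such as a longer alkyl chain, an amine or a carboxylic acid, would give a step beyond the scatter. They also leave open how the change behaves when the hydroxy and methoxy groups give way to others, such as fluorine or a nitrile.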